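This account rests on a few compounds, and the source may have more. Where it says the series, first, only, none or still open, it means among the compounds named here.

In a functional assay on KB cells (Homo sapiens) for inhibition (a lower number here means a stronger inhibitor, a higher number a weaker inhibitor), compound 1 (`N#Cc1c(N)n(COCc2ccccc2)c2ncnc(N)c12`) gives 118000 nM as a measured number. Compound 2 (`N#Cc1c(Br)n(COCc2ccccc2)c2ncnc(N)c12`) reads > 100000 nM and this is a limit, not a number. Going by these compounds, compound 2 thus stands at the limit of > 100000 nM in this assay, at which 2 of the 3 values shown sit, and its exact value is unknown. Compound 4 (`CCOCn1c(Br)c(C#N)c2c(N)ncnc21`) differs from it as follows: methyl in place of phenyl on a saturated chain carbon bound to an oxygen on a saturated carbon (methyl in place of phenyl, which also reads as benzyl to ethyl). Among the compounds with values here, the only measured step is a step that the limit leaves unreadable from compound 1 to compound 2 and it concerns another group, so it sets no size for this change. Compound 3 (`COCCOCn1c(N)c(C(N)=O)c2c(N)ncnc21`) has no phenyl and reads > 100000 nM and this too is a limit. In this assay the estimated step that the limit leaves unreadable from compound 2 to compound 4 is small and has no clear direction. Compound 4 is expected near 150000 nM with an estimated range of 60000 nM to 400000 nM and a reading at the limit is likely.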

Compound 4, half-maximal inhibitory concentration: > 100000 nM
Compound 4: no number, only a limit; the forecaster's own chance of this, stated with the estimate: 75%; the middle value does not contradict the limit.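

Compound 2 and compound 4 both give only a limit in this assay and no number, so the step between them cannot be read: the limit of > 100000 nM in this assay, at which 3 of the 4 values shown sit.

Going by these compounds, whether methyl in place of phenyl changes inhibition at all stays open.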